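Side-chain variation on the shared core

The source may hold more compounds than are shown below. What is called first, only, known or untested is meant among the compounds shown, and "the series" means these compounds.

Measured so far:
compound 1 `C=C1[C@H](C)CCC[C@]1(C)CC/C(C)=C/CC1=C(O)C(=O)C=C(N[C@H](C(=O)O)[C@@H](C)O)C1=O`: > 10 ug/mL
compound 2 `C=C1[C@H](C)CCC[C@]1(C)CC/C(C)=C/CC1=C(O)C(=O)C=C(N[C@@H](C(=O)O)[C@@H](C)O)C1=O`: > 10 ug/mL

In an ADME assay on KB cells (Homo sapiens) for cytotoxicity, with a stated time of 48 h (a higher number here means a weaker inhibitor, a lower number a stronger inhibitor), compound 1 gives only a limit, > 10 ug/mL. Compound 2 likewise gives only a limit, > 10 ug/mL. The step that the two limits leave unreadable from compound 1 to compound 2 is therefore not readable, since both values sit at the limit of > 10 ug/mL in this assay, at which 2 of the 2 values shown sit, and the pair differs only in the fact that compounds 1 and 2 differ only in the configuration as drawn. Compound 2 thus stands at a limit in this assay, with no number that places it.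

Compound 3 `C=C1[C@H](C)CCC[C@]1(C)CC/C(C)=C/CC1=C(O)C(=O)C=C(N[C@H](C(=O)O)C(C)C)C1=O` carries 1-carboxy-2-methylpropyl in place of 1-carboxy-2-hydroxypropyl on an amine nitrogen. Among the measured compounds shown here, no measured step bears on this change; the single measured step is unreadable, so nothing here points to a direction or size beyond the scatter. In this assay the expected step is a step that the limit leaves unreadable from compound 2 to compound 3, an estimate resting on the limits alone. Compound 3 is estimated at 15 ug/mL, within 5 ug/mL to 50 ug/mL, and is expected most probably to be reported again only as a limit.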

Compound 3, half-maximal inhibitory concentration: > 10 ug/mL
Compound 3: a limit, no number (the forecaster's own chance of this, stated with the estimate: 75%); the middle value lies beyond the limit too.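

In this assay compound 3 gives only a limit, > 10 ug/mL. Among the compounds shown here, no step from compound 1 or compound 2 to compound 3 can be read: the limit of > 10 ug/mL in this assay, at which 3 of the 3 values shown sit. On these data alone, how compound 1, compound 2 and compound 3 rank against one another in this assay stays open.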